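This account rests on a few compounds, and the source may have more. Where it says the series, first, only, none or still open, it means among the compounds named here.

Measured so far in a functional assay on C6 cells (Rattus norvegicus), read by thymidine incorporation; a lower number here means a stronger inhibitor, a higher number a weaker inhibitor:
compound 1, `CCCCCCCCCCCCCCCCO[C@H]1O[C@H](CO)[C@@H](O)[C@H](O)[C@H]1NC(C)=O`: 13 uM
compound 2, `CCCCCCCC/C=C\CCCCCCCC(=O)N[C@H]1[C@@H](OCCCCCCCC)O[C@H](CO)[C@@H](O)[C@@H]1O`: 12 uM
compound 3, `CCCCCCCC/C=C\CCCCCCCC(=O)N[C@H]1[C@@H](OCCCCCCCC)O[C@H](CO)[C@@H](O)[C@@H]1OS(=O)(=O)O`: 5.4 uM

Compound 2 gives the second highest number of the three. Going by the values given here, compound 1 lies within the scatter of it; compound 3 is the only measured compound that differs from compound 2 by a step beyond the scatter, a 2.2-fold lower number from compound 2 to compound 3 (0.35 log units; beyond the scatter), a modest lowering.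

Compound 4, `CCCCCCCC/C=C\CCCCCCCC(=O)N[C@H]1[C@@H](OCCCCCCCC)O[C@H](COS(=O)(=O)O)[C@@H](O)[C@@H]1O`, is the second sulfated form of compound 2: sulfo in place of hydrogen on an oxygen on a saturated carbon. Among the compounds with values here, the one measured step that bears on it is the sulfation of compound 2 at its other free oxygen, a 2.2-fold lower number from compound 2 to compound 3 (0.35 log units; beyond the scatter). Going by these compounds, whether sulfation of the hydroxymethyl to (sulfooxy)methyl behaves the same way is untested, and with a single relevant step the expectation rests on compound 3 alone. The expected direction is therefore a modest lowering, of about the size seen for compound 3, with the range widened to allow for no change beyond the scatter.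

Compound 4 is expected to give 7 uM, within 3.5 uM to 14 uM, which means an expected step of a 1.7-fold lower number from compound 2 to compound 4 (0.23 log units; within the scatter).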

Compound 4, concentration for 50% inhibition: 5.6 uM
Beside the measured number, compound 4's estimate is 1.3-fold (0.10 log units) above it; low and high end bracket the measured number.
By their numbers in this assay, from the lowest: compounds 3 and 4 (each within the scatter of the next); then compounds 2 and 1 (each within the scatter of the next).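

In this assay, sulfo in place of hydrogen on the oxygen of the hydroxymethyl group of compound 2 also gives a modest lowering (a 2.1-fold lower number from compound 2 to compound 4 (0.33 log units; beyond the scatter)), so the lowering is no longer tied to the single oxygen behind the earlier step (a 2.2-fold lower number from compound 2 to compound 3 (0.35 log units; beyond the scatter)). The two sulfated forms stand within the scatter of each other, with compound 3 at 5.4 uM and compound 4 at 5.6 uM, so no preference between these two oxygens can be read in this assay. Nothing at hand accounts for the lowering at either oxygen.

Open, going by these compounds, is whether a carboxylic acid or a phosphate on the same oxygen would give a step of like size. Also open, on these data alone, is whether sulfooxy at both oxygens of the shared core would lower the number further.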